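The compounds below may be only part of what the source reports. "The series", "measured", "known", "first", "only" and "open" are said of these compounds alone.

Measured in a functional assay on DU-145 cells (Homo sapiens) for cytotoxicity, read by trypan blue exclusion, with a stated time of 96 h; a lower number here means a stronger inhibitor, a higher number a weaker inhibitor:
- Compound 1 `COC(=O)C(C)(C)Nc1cc(NS(=O)(=O)/C=C/c2c(OC)cc(OC)cc2OC)ccc1OC`: 200 nM
- Compound 2 `COC(=O)C(Nc1cc(NS(=O)(=O)/C=C/c2c(OC)cc(OC)cc2OC)ccc1OC)c1ccc(F)cc1`: 2500 nM
- Compound 3 `COc1cc(OC)c(/C=C/S(=O)(=O)Nc2ccc(OC)c(NC(C)C(=O)O)c2)c(OC)c1`: 40 nM

Compound 3 has the lowest number of the three, and its gaps to both others lie beyond the scatter. Compound 4 `COc1cc(OC)c(/C=C/S(=O)(=O)Nc2ccc(OC)c(NC(C(=O)O)c3ccc(Cl)cc3)c2)c(OC)c1` differs from it by 4-chlorophenyl in place of methyl on a saturated chain carbon bound to a carbonyl carbon and a nitrogen on an aromatic ring, with 4-chlorophenyl in place of methyl on a saturated chain carbon bound to a carbonyl carbon and a nitrogen on an aromatic ring.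

Going by the values given here, no measured pair isolates this change. The closest guide is the large 13-fold higher number from compound 1 to compound 2 (1.10 log units; beyond the scatter), where a ring-bearing group also enters, though with methoxycarbonyl groups on both sides. The large 63-fold lower number from compound 2 to compound 3 (1.80 log units; beyond the scatter) points the same way, but it combines loss of the ring with the switch to 1-carboxyethyl. The modest 5.0-fold lower number from compound 1 to compound 3 (0.70 log units; beyond the scatter) also involves that switch.

A step to a higher number, beyond the scatter, is therefore expected in this assay. The expected change is a 7.5-fold higher number from compound 3 to compound 4 (0.88 log units; beyond the scatter). Compound 4 is estimated at 300 nM, with an expected range of 70 nM to 1300 nM.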

Compound 4, half-maximal inhibitory concentration: 75 nM
For compound 4 the middle estimate is 4.0-fold (0.60 log units) above the measured one, within the range that was stated.
By their numbers in this assay, from the lowest: compounds 3 and 4 (each within the scatter of the next); then compound 1; then compound 2.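

In this assay, 4-chlorophenyl in place of methyl on a saturated chain carbon bound to a carbonyl carbon and a nitrogen on an aromatic ring gives a 1.9-fold higher number from compound 3 to compound 4 (0.27 log units; within the scatter), so with a free carboxy group on this carbon an aromatic ring can enter without a step beyond the scatter. Until now a ring at this carbon stood only in the methyl ester compound 2, and two steps that each change more than one feature now appear: the large 33-fold lower number from compound 2 to compound 4 (1.52 log units; beyond the scatter) and the modest 2.7-fold lower number from compound 1 to compound 4 (0.43 log units; beyond the scatter). Nothing given here accounts for this result.

From the compounds shown here alone, it remains open how an unsubstituted phenyl, a benzyl group or a longer alkyl chain would read on this carbon. Also open, going by these compounds, is how an amide in place of the carboxy group would read.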